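A few compounds are considered here, and "the series" means these few. Any claim that something is new, unique, unknown or untested is made for them only; others in the source may bear on it.

Working notes on the series, cytotoxicity arm.

Compound 1 `O=C(O)CCC(=O)OCCCCCCSc1ccc([N+](=O)[O-])c2nonc12` is the acid of the pair; in an ADME assay on HUVEC cells (Homo sapiens) for cytotoxicity, read by MTT assay, with a stated time of 72 h (a higher number here means a weaker inhibitor, a lower number a stronger inhibitor), compound 1 gives 740 nM. Going by the values given here, compound 2 `Cc1ccc(NC(=O)CCC(=O)OCCCCCCSc2ccc([N+](=O)[O-])c3nonc23)cc1` carries the aryl amide, and in this assay compound 2 gives 2340 nM, the highest of the two numbers so far; the step of a 3.2-fold higher number from compound 1 to compound 2 (0.50 log units; beyond the scatter) is the only measured step in this set.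

Compound 3 `COc1ccc(NC(=O)CCC(=O)OCCCCCCSc2ccc([N+](=O)[O-])c3nonc23)cc1OC` is not yet measured. The change from compound 2 is 3,4-dimethoxyphenyl in place of 4-methylphenyl on an amide-type nitrogen. Among the compounds with values here, no measured step exchanges one aryl group for another on the amide nitrogen; the only step that touches this part of the molecule is a 3.2-fold higher number from compound 1 to compound 2 (0.50 log units; beyond the scatter), which concerns the amide itself and not the substituent on its aryl ring. Without a directly comparable step, the expectation for compound 3 is a number close to that of compound 2, with no move beyond the scatter: the step is estimated as a 1.1-fold higher number from compound 2 to compound 3 (0.03 log units; within the scatter). Compound 3 is therefore expected at about 2500 nM in this assay, with a range of 1000 nM to 6500 nM.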

Compound 3, half-maximal inhibitory concentration: 870 nM
Compound 3: the middle estimate sits 2.9-fold (0.46 log units) above what was measured; the measured number lies below the stated range.
By their numbers in this assay, from the lowest: compounds 1 and 3 (each within the scatter of the next); then compound 2.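

In this assay, 3,4-dimethoxyphenyl in place of 4-methylphenyl on an amide-type nitrogen gives a 2.7-fold lower number from compound 2 to compound 3 (0.43 log units; beyond the scatter) and shows that the aryl group on this nitrogen, not the amide alone, moves the number. The higher number of compound 2 against the acid, compound 1, therefore does not hold for both aryl amides: (3,4-dimethoxyphenyl)amino in place of hydroxy on a carbonyl carbon gives a 1.2-fold higher number from compound 1 to compound 3 (0.07 log units; within the scatter) and leaves the two compounds level. No measurement at hand accounts for the difference between the two aryl groups.

Going by these compounds alone, with only two aryl groups, the change cannot be divided between the loss of the methyl group and the gain of the two methoxy groups. On these data alone, whether plain phenyl or 4-methoxyphenyl on this nitrogen would fall with compound 2 or with compound 3 stays open.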